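The source may hold more compounds than are shown below. What is called first, only, known or untested is meant among the compounds shown, and "the series" means these compounds.

Working notes on the series. Going by the values given here, in a functional assay (strain AB) with Danio rerio as the target, read by microscopy, with a stated time of 1 h (on this read-out lower numbers stand for an effect already at smaller amounts and higher numbers for an effect only at larger amounts of compound), compound 1 (`CC(C)(C)OC(=O)CCCC[N+]1(C)CCc2c(sc(NC(=O)Nc3ccc(Cl)cc3)c2C(N)=O)C1`) gives 140 nM, the lower of the two numbers measured so far. Compound 2 (`CCN1CCc2c(sc(NC(=O)Nc3ccc4ccccc4c3)c2C(N)=O)C1`) gives 1780 nM, a gap beyond the scatter. These two compounds differ in more than one place, so their gap gives no size for any single change.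

Compound 3 (`C[N+]1(CC2CCC2)CCc2c(sc(NC(=O)Nc3ccc(Cl)cc3)c2C(N)=O)C1`) keeps the core of compound 1 and differs in one place: cyclobutyl in place of 3-(tert-butoxycarbonyl)propyl on a saturated chain carbon bound to an amine nitrogen in a ring. In words, cyclobutyl stands in place of 3-(tert-butoxycarbonyl)propyl on a saturated chain carbon bound to an amine nitrogen in a ring. Cut one bond further out, the same difference reads 4-(tert-butoxycarbonyl)butyl to cyclobutylmethyl.

Among the compounds with values here, no measured pair isolates this change, so the expectation is weakly founded. Starting from compound 1 at 140 nM, a moderate move to a higher number is expected, though a result within the scatter would not be surprising. The expected step in this assay is a 2.0-fold higher number from compound 1 to compound 3 (0.30 log units; within the scatter). For compound 3 the estimated value is 280 nM, with an expected range from 60 nM to 1300 nM.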

Compound 3, half-maximal effective concentration: 210 nM
For compound 3 the middle estimate is 1.3-fold (0.12 log units) above the measured one; the range from low to high includes it.
By their numbers in this assay, from the lowest: compounds 1 and 3 (each within the scatter of the next); then compound 2.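

In this assay, cyclobutyl in place of 3-(tert-butoxycarbonyl)propyl on a saturated chain carbon bound to an amine nitrogen in a ring gives a 1.5-fold higher number from compound 1 to compound 3 (0.18 log units; within the scatter) and so provides the first size for a single change in this series. On this read-out, compound 1 and compound 3 are not separated, even though the 10 heavy atoms, 2 hydrogen-bond acceptors and double bond of the leaving group give way to the 4 carbon atoms and four-membered ring of cyclobutyl. This position therefore admits both groups without a difference beyond the scatter, but that finding rests on this one pair, and no accompanying measurement offers an explanation for it.

On these data alone, it remains open how this position responds to a carboxylic acid at the end of the chain, a terminal primary amine, or a plain unbranched alkyl chain of greater length. The compounds shown also leave unresolved how the gap to compound 2 divides among the places in which it differs from compound 1 and compound 3.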